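This account rests on a few compounds, and the source may have more. Where it says the series, first, only, none or still open, it means among the compounds named here.

Measured in a functional assay on A549 cells (Homo sapiens) for antiproliferative activity, read by MTT assay, with a stated time of 72 h; a higher number here means a weaker inhibitor, a lower number a stronger inhibitor:
- Compound 1 `CCNC(=O)c1cc(Oc2ccc(NC(=O)c3nn(-c4ccc(Br)cc4F)c(=O)cc3C)cc2)ccn1`: 34500 nM
- Compound 2 `CCNC(=O)c1cc(Oc2ccc(NC(=O)c3nn(-c4cccc(F)c4)c(=O)cc3C)cc2)ccn1`: 7410 nM
- Compound 3 `CNC(=O)c1cc(Oc2ccc(NC(=O)c3nn(-c4ccccc4Cl)c(=O)cc3C)cc2F)ccn1`: 11800 nM

Compound 3, at 11800 nM, lies within the usual scatter of compound 2, at 7410 nM. Its number is clearly lower than that of compound 1, at 34500 nM.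

The next compound is compound 4 `CNC(=O)c1cc(Oc2ccc(NC(=O)c3nn(-c4cccc(C(F)(F)F)c4)c(=O)cc3C)cc2F)ccn1`, which carries 3-(trifluoromethyl)phenyl in place of 2-chlorophenyl on an aromatic nitrogen.

Among the compounds with values here, only one measured step changes this same place: a 4.7-fold lower number from compound 1 to compound 2 (0.67 log units; beyond the scatter), a modest step that replaced 4-bromo-2-fluorophenyl with 3-fluorophenyl. It is only a loose guide, since compound 1 and compound 2 also differ from compound 3 elsewhere in the core. Within the data shown here, no measured step starts from 2-chlorophenyl. Compound 2, with its single substituent at the 3-position of the phenyl ring, gives 7410 nM, so no large move is expected in this assay.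

The expected change is a 1.3-fold lower number from compound 3 to compound 4 (0.12 log units; within the scatter), which would not go beyond the scatter. For compound 4 the estimated value is 9000 nM, with an expected range of 3500 nM to 25000 nM.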

Compound 4, half-maximal inhibitory concentration: 10200 nM
The estimate for compound 4 lay 1.1-fold (0.05 log units) below the measured number, and the stated range covers the measured number.
By their numbers in this assay, from the lowest: compounds 2, 4 and 3 (each within the scatter of the next); then compound 1.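

In this assay, putting 3-(trifluoromethyl)phenyl in place of 2-chlorophenyl on the aromatic nitrogen gives a 1.2-fold lower number from compound 3 to compound 4 (0.06 log units; within the scatter), so the two compounds cannot be told apart. Within the data shown here, the only earlier step at this position, a 4.7-fold lower number from compound 1 to compound 2 (0.67 log units; beyond the scatter), lay beyond the scatter, whereas this one shows that on the core of compound 3 a group of 10 heavy atoms can replace one of 7 with no readable shift in the number. Nothing measured here explains this result.

The compounds shown leave open whether a phenyl ring carrying an amine or a carboxylic acid, or a cyclohexyl group in place of the phenyl ring, would also stay within the scatter at this position. They also leave open whether the same exchange would give a similar result on the core of compound 1.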